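Capping the Hydroxy Group of Compound 1 with Methyl

The source may report more compounds than this note shows. Statements on the series, on what has been measured and on what is new or still open speak of the compounds shown alone.

Compound 1 `O=C(NCCCNc1cc(-c2cn(-c3ccccc3)nc2-c2cccc(O)c2)ccn1)Nc1ccc(F)cc1`: 11000 nM
Compound 2 `O=C(NCCCNc1cc(-c2cn(-c3ccccc3)nc2-c2cccc(O)c2)ccn1)Nc1cccc(C(F)(F)F)c1`: 16700 nM

Going by the values given here, in a functional assay on T47D cells (Homo sapiens) for antiproliferative activity, read by sulforhodamine B assay, with a stated time of 48 h (on this read-out lower numbers stand for stronger inhibition of growth and higher numbers for weaker inhibition of growth), compound 1 stands level with compound 2, the only other compound measured so far, as the two cannot be separated beyond the usual scatter. Among the compounds with values here, the single measured step is a 1.5-fold higher number from compound 1 to compound 2 (0.18 log units; within the scatter). That step swaps one aromatic group on an amide-type nitrogen for another, so it concerns a different part of the molecule from the change considered here.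

Compound 3 `COc1cccc(-c2nn(-c3ccccc3)cc2-c2ccnc(NCCCNC(=O)Nc3ccc(F)cc3)c2)c1` has not yet been measured. It differs from compound 1 by methyl in place of hydrogen on an oxygen on an aromatic ring, which turns 3-hydroxyphenyl into 3-methoxyphenyl.

Within the data shown here, no measured step touches this oxygen, so the data give no direction for the change. The best anchor is therefore compound 1 at 11000 nM, with a wide margin on both sides. The expected step is a 1.2-fold higher number from compound 1 to compound 3 (0.07 log units; within the scatter), so no clear shift beyond the scatter is anticipated. For compound 3 the estimated value is 13000 nM, with an expected range from 5500 nM to 30000 nM.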

Compound 3, concentration for total growth inhibition: > 37000 nM
Compound 3: a limit, no number; the forecaster's own chance of this, stated with the estimate: 10%; middle value at least 2.8-fold (0.45 log units) away from the limit.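

In this assay, going by these compounds alone, the step from hydroxy to methoxy is the first measured change at this oxygen, and it gives an at least 3.3-fold higher number from compound 1 to compound 3 (0.52 log units; beyond the scatter). This position therefore responds to the change, and the shift is towards weaker inhibition of growth, unlike the swap of aromatic groups on the amide-type nitrogen, which gives a 1.5-fold higher number from compound 1 to compound 2 (0.18 log units; within the scatter). Compound 3 gives > 37000 nM, which is a limit and not a number, so the full size of the step stays unknown: the limit of > 37000 nM in this assay, at which 1 of the 3 values shown sits.

One replacement cannot separate the loss of the hydrogen on the oxygen from the arrival of the methyl, and an amine in place of the hydroxy group, or an ethoxy group in place of the methoxy group, would help to tell these two apart. Going by these compounds, it also remains open whether the same change has a similar effect when the 4-fluorophenyl group is replaced by the 3-(trifluoromethyl)phenyl group of compound 2.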